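This account rests on a few compounds, and the source may have more. Where it says the series, first, only, none or still open, it means among the compounds named here.

Working notes on the furan-carboxamide series.

Compound 1 `Cc1ccc(F)cc1N(C)C(=O)c1ccc(-c2ccc(O)cc2)o1` gives 41 nM in an assay on cytosol from placenta for inhibition of 17-beta-hydroxysteroid dehydrogenase type 1 (Homo sapiens), read by HPLC, with a stated time of 10 min, in the presence of a further agent that is not named here (on this read-out higher numbers stand for weaker inhibition and lower numbers for stronger inhibition), and stands as the lowest of the two numbers recorded so far. Compound 2 `Cc1c(F)cccc1N(C)C(=O)c1ccc(-c2ccc(O)cc2)o1` differs from compound 1 only in the substitution pattern of the phenyl ring on the amide-type nitrogen. In this assay compound 2 gives 170 nM; the step of a 4.1-fold higher number from compound 1 to compound 2 (0.62 log units; beyond the scatter) is beyond the scatter but modest.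

Compound 3 `Cc1ncccc1N(C)C(=O)c1ccc(-c2ccc(O)cc2)o1` is not yet measured. It differs from compound 1 by 2-methylpyridin-3-yl in place of 5-fluoro-2-methylphenyl on an amide-type nitrogen. Within the data shown here, no measured pair covers this exchange of fluorophenyl for methylpyridinyl; the single step available, a 4.1-fold higher number from compound 1 to compound 2 (0.62 log units; beyond the scatter), shows only that altering the aryl group on this nitrogen costs a modest amount of inhibition while keeping the compound in the same range. Read against that, the change to compound 3 is expected to give a small to modest weakening, possibly none beyond the scatter.

Compound 3 is therefore estimated at 90 nM in this assay, with a range of 35 nM to 250 nM. That estimate means an expected step of a 2.2-fold higher number from compound 1 to compound 3 (0.34 log units; beyond the scatter).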

Compound 3, half-maximal inhibitory concentration: 160 nM
The estimate for compound 3 lay 1.8-fold (0.25 log units) below the measured number, and the stated range covers the measured number.
By their numbers in this assay, from the lowest: compound 1; then compounds 3 and 2 (each within the scatter of the next).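

In this assay, 2-methylpyridin-3-yl in place of 5-fluoro-2-methylphenyl on the amide-type nitrogen gives a 3.9-fold higher number from compound 1 to compound 3 (0.59 log units; beyond the scatter), so this exchange of a carbon-only ring for a ring with one hetero atom, which also removes the fluorine, costs a modest amount of inhibition. The same exchange starting from 3-fluoro-2-methylphenyl gives a 1.1-fold lower number from compound 2 to compound 3 (0.03 log units; within the scatter), so compounds 2 and 3 cannot be told apart on this read-out, and among the three aryl groups only the 5-fluoro-2-methylphenyl of compound 1 stands apart from the others. Nothing in hand accounts for this difference between the aryl groups.

On these data alone, it remains open whether a fluorine placed on the 2-methylpyridin-3-yl ring would bring the number back towards that of compound 1, which would separate the effect of the ring nitrogen from that of the lost fluorine. Also open, as far as these compounds go, is how the position responds when the ring methyl is replaced by a chlorine or a methoxy group, or when an ethyl chain replaces the methyl on the amide-type nitrogen.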